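The source may report more compounds than this note shows. Statements on the series, on what has been measured and on what is new or still open speak of the compounds shown alone.

Compound 1, `COC(=O)[C@@]1(C)CCC=C2[C@@H]1CC[C@@H](C)[C@]2(C)Cc1c[nH]c2c(Cl)cccc12`, and compound 2, `COC(=O)[C@@]1(C)CCC=C2[C@@H]1CC[C@@H](C)[C@]2(C)Cc1c(C)[nH]c2c(Cl)cccc12`, share one core, while compound 3, `COC(=O)[C@@]1(C)CC[C@@H]2C3=C1CC[C@@H](C)[C@]3(C)C[C@@H]1c3ccccc3N[C@H]21`, and compound 4, `COC(=O)[C@@]1(C)CC[C@@H]2C3=C1CC[C@@H](C)[C@]3(C)C[C@@H]1c3cccc(C)c3N[C@H]21`, share another; the difference between the two cores is not broken down here. In a functional assay on WiDr cells (Homo sapiens) for inhibition, read by sulforhodamine B assay, with a stated time of 48 h (a lower number here means a stronger inhibitor of growth, a higher number a weaker inhibitor of growth), compound 1 gives 31000 nM, and compound 2 gives 29000 nM. Compound 2 differs from compound 1 by methyl in place of hydrogen on an aromatic carbon, and that change brings a 1.1-fold lower number from compound 1 to compound 2 (0.03 log units; within the scatter). Compound 3 gives 50000 nM in this assay, and its values against compound 1 and compound 2 lie within the usual scatter, so no ordering among the three is drawn.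

Compound 4 differs from compound 3 by methyl in place of hydrogen on an aromatic carbon. Among the measured compounds shown here, this is the same kind of change as the one from compound 1 to compound 2, though not the same: there the methyl entered on a five-membered aromatic ring with one nitrogen, next to the ring nitrogen and next to the ring atom that bears a large group, whereas here it enters on a six-membered aromatic ring of carbon only, ortho to a fused ring and meta to a fused ring. Resting on compound 3 at 50000 nM and on the small step seen with a 1.1-fold lower number from compound 1 to compound 2 (0.03 log units; within the scatter), the expected step is a 1.1-fold lower number from compound 3 to compound 4 (0.05 log units; within the scatter). Compound 4 is therefore estimated at 45000 nM, with a likely range from 20000 nM to 100000 nM in this assay.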

Compound 4, concentration for 50% growth inhibition: 43000 nM
Compound 4: middle estimate off by 1.0-fold (0.02 log units), on the high side; low and high end bracket the measured number.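

In this assay, methyl in place of hydrogen on an aromatic carbon brings a 1.2-fold lower number from compound 3 to compound 4 (0.07 log units; within the scatter), and the step on this core does not differ from the one on the core of compound 1: the same change on two cores in this assay, a 1.1-fold lower number (0.03 log units; within the scatter) from compound 1 to compound 2 and a 1.2-fold lower number (0.07 log units; within the scatter) from compound 3 to compound 4, 1.1-fold (0.04 log units) apart, within the scatter of two such steps. Within these two pairs, then, the methyl change carries from one core to the other without a readable difference, and on neither core does it separate the two compounds of the pair. This does not show that the two cores respond alike to changes in general: both steps lie within the scatter, the methyl sits on a different kind of aromatic ring in each pair, and a change that leaves the number unmoved on both cores cannot reveal how far a larger step would transfer.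

The compounds shown hold only hydrogen or methyl at these two places, so it remains open whether an amine, a carboxylic acid or a longer chain such as ethyl or propyl there would move the number beyond the scatter on either core. All four compounds also keep the same methyl ester, which leaves open what a carboxylic acid or an amide at that place would do in this assay.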